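The compounds below may be only part of what the source reports. "The series", "measured", "known", "first", "only" and "open" are said of these compounds alone.

- compound 1 `COc1cc(/C=C/C(=O)/C=C/c2cccs2)ccc1OCc1cn(CCOc2cc(=O)oc3ccccc23)nn1`: 76%
- compound 2 `COc1cccc(/C=C/C(=O)/C=C/c2ccc(OCc3cn(CCCCOc4cc(=O)oc5ccccc45)nn3)c(OC)c2)c1`: 47%

In a functional assay on THP-1 cells (Homo sapiens) for inhibition, read by sulforhodamine B assay, with a stated time of 48 h, tested at 50 uM (on this read-out lower numbers stand for less inhibition of growth and higher numbers for more inhibition of growth at the one concentration tested), compound 1 stands highest of the two measured compounds at 76%, and compound 2 gives 47%. Compound 2 lies lower than compound 1, and that gap is beyond the usual scatter. Compound 3 `COc1ccc(/C=C/C(=O)/C=C/c2ccc(OCc3cn(CCOc4cc(=O)oc5ccccc45)nn3)c(OC)c2)cc1OC` has not yet been measured. It differs from compound 1 as follows: 3,4-dimethoxyphenyl in place of thiophen-2-yl on a double-bonded chain carbon bound to a double-bonded chain carbon. Here 3,4-dimethoxyphenyl replaces thiophen-2-yl on a double-bonded chain carbon bound to a double-bonded chain carbon. For the measured compounds named here, no measured pair isolates this change, and compound 2 at 47% differs from compound 1 in more than one place, so it is only a loose guide. A moderate fall in growth inhibition is expected, slightly beyond the scatter, and the expected step is a number 14 percentage points lower from compound 1 to compound 3 (beyond the scatter). For compound 3 the estimated value is 62%, with an expected range of 40% to 82%.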

Compound 3, percent growth inhibition at one concentration: 90%
Beside the measured number, compound 3's estimate is 28 percentage points below it; measured number outside the range, above it.
By their numbers in this assay, from the lowest: compound 2; then compound 1; then compound 3.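

In this assay, for the compounds shown here, putting 3,4-dimethoxyphenyl in place of thiophen-2-yl gives a number 14 percentage points higher from compound 1 to compound 3 (beyond the scatter), the first reading of this single change on the double-bonded chain carbon. So, with the rest of the molecule held constant, this place accepts the larger six-membered ring without any loss of growth inhibition, and the thiophene sulfur is not needed to reach these numbers. Nothing available here accounts for the size or direction of this step. Still open, on these data alone, is whether both methoxy groups are needed, as an unsubstituted phenyl would begin to show. How a ring carrying an amine or a carboxylic acid would behave at this place is also unknown.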